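Biaryl amide hexanoic acids: cytotoxicity on Raji cells

This account rests on a few compounds, and the source may have more. Where it says the series, first, only, none or still open, it means among the compounds named here.

Measured so far:
compound 1 `CC(C)N(Cc1cccc(OCCCCCC(=O)O)c1)C(=O)c1ccc(-c2cccc3ccccc23)cc1`: > 26000 nM
compound 2 `CC(C)N(Cc1cccc(OCCCCCC(=O)O)c1)C(=O)c1ccc(-c2ccc3c(c2)OCCO3)cc1`: > 21900 nM

In an ADME assay on Raji cells (Homo sapiens) for cytotoxicity, read by CellTiter-Glo and resazurin assay, with a stated time of 72 h (a higher number here means that more compound is needed for the effect, a lower number that less compound is needed), compound 1 gives only a limit, > 26000 nM. Compound 2 likewise gives only a limit, > 21900 nM. The step that the two limits leave unreadable from compound 1 to compound 2 is therefore unreadable; the two values sit at the limit of > 26000 nM in this assay, at which 1 of the 2 values shown sits, and at the limit of > 21900 nM in this assay, at which 1 of the 2 values shown sits. Compound 2 thus stands at a limit of this assay, with no number beside it.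

Compound 3 `CC(C)N(Cc1cccc(OCCCCCC(=O)O)c1)C(=O)c1ccc(-c2ccc3cc[nH]c3c2)cc1` differs from compound 2 by 1H-indol-6-yl in place of 2,3-dihydro-1,4-benzodioxin-6-yl on an aromatic carbon. No readable measured step bears on this change. No step beyond the scatter is expected in this assay, the estimated step being a step that the limit leaves unreadable from compound 2 to compound 3. Compound 3 is expected to give 25000 nM, between 8000 nM and 80000 nM, most probably again reported as a limit.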

Compound 3, half-maximal effective concentration: > 26000 nM
Compound 3 ended at the assay's limit; the forecaster's own chance of this, stated with the estimate: 80%; middle value at least 1.0-fold (0.01 log units) from the limit.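

Within the data shown here, compound 1, compound 2 and compound 3 all give only limits in this assay, so no step among them can be read. On these data alone, the concentration at which any of them reaches half-maximal effect remains open.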